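From a Cyclobutyl Ester to a Diethyl Amide

The source may hold more compounds than are shown below. What is called first, only, known or untested is meant among the compounds shown, and "the series" means these compounds.

Measured so far:
compound 1 `CCCOC(=O)/C=C(C)/C=C/CC(C)CCCC(C)(C)OC` – 6.08
compound 2 `COC(C)(C)CCCC(C)C/C=C/C(C)=C/C(=O)OC1CCC1` – 6.44
compound 3 `CCNC(=O)OC(C)(C)CCCC(C)C/C=C/C(C)=C/C(=O)OCC` – 5.65

Of the compounds shown here, three share one long chain and have been measured in a physicochemical assay for lipophilicity; on this read-out lower numbers stand for lower lipophilicity and higher numbers for higher lipophilicity. Compound 2 stands highest of the three: compound 1 lies a small way below it, and compound 3 lies further below. Among the measured compounds shown here, the one step between neighbours that differ in a single place, a number 0.36 log units higher from compound 1 to compound 2 (beyond the scatter), came with cyclobutyl in place of propyl on an oxygen next to a carbonyl group.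

Compound 4 `CCN(CC)C(=O)/C=C(C)/C=C/CC(C)CCCC(C)(C)OC` has not yet been measured. It differs from compound 2 in one place: diethylamino in place of cyclobutyloxy on a carbonyl carbon. Cut one bond further out, the same change reads cyclobutyloxycarbonyl to diethylcarbamoyl.

For the measured compounds named here, no measured step covers this kind of change. The step from compound 1 to compound 2 swaps one carbon group for another on the same oxygen and keeps the oxygen; here the oxygen itself leaves and a nitrogen enters. Compound 3 carries a different group at the far end of the chain, so its value gives no direct guide either. On general experience with this type of exchange, a step downward in this assay is expected, a number 1.44 log units lower from compound 2 to compound 4 (beyond the scatter), and compound 4 is estimated at 5, between 4.4 and 5.6.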

Compound 4, partition coefficient: 4.82
Beside the measured number, compound 4's estimate is 0.18 log units above it, and the stated range covers the measured number.
By their numbers in this assay, from the lowest: compound 4; then compound 3; then compound 1; then compound 2.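

In this assay, the number at this carbonyl carbon moves much further when the atom attached to the carbonyl changes than when only the carbon group on the oxygen changes: replacing oxygen-linked cyclobutyloxy with nitrogen-linked diethylamino gives a large step (a number 1.62 log units lower from compound 2 to compound 4 (beyond the scatter)), whereas the swap between two oxygen-linked groups gave a modest one (a number 0.36 log units higher from compound 1 to compound 2 (beyond the scatter)). The large fall also appears when the group that leaves is open-chain propoxy (a number 1.26 log units lower from compound 1 to compound 4 (beyond the scatter)), so it does not depend on the loss of the four-membered ring found in cyclobutyloxy. No supporting measurement is available to explain why this exchange has so large an effect.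

The compounds shown leave open how the number would respond to other groups on this carbonyl carbon, such as dimethylamino, a ring amine like pyrrolidinyl, or the hydroxyl of a free carboxylic acid. They also leave open whether an exchange of an oxygen-linked group for diethylamino would give a step of similar size in a compound carrying the different far-end group of compound 3.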